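This account rests on a few compounds, and the source may have more. Where it says the series, first, only, none or still open, it means among the compounds named here.

Measured so far in an assay for binding affinity to 17-beta-hydroxysteroid dehydrogenase type 2 (Homo sapiens), read by scintillation counting, with a stated time of 10 min, tested at 1 uM; on this read-out higher numbers stand for more inhibition at the one concentration tested (going by the name of the read-out) and lower numbers for less inhibition:
compound 1, `Oc1cccc(-c2ccc3c(-c4cncnc4)c(O)ccc3c2)c1`: 85%
compound 2, `Oc1ccc2cc(-c3ccccc3)ccc2c1-c1cncnc1`: < 10%
compound 3, `Oc1ccccc1-c1ccc2c(-c3cncnc3)c(O)ccc2c1`: < 10%

Compound 3 stands at a limit of this assay and not at a number; its < 10% is the floor of the read-out. Compound 2 also returns only a limit, (the limit of < 10% in this assay, at which 2 of the 3 values shown sit). Compound 1 alone gives a full number, 85%.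

Compound 4, `Oc1ccc(-c2ccc3c(-c4cncnc4)c(O)ccc3c2)cc1`, is not yet measured. It differs from compound 3 in one place: 4-hydroxyphenyl in place of 2-hydroxyphenyl on an aromatic carbon.

For the measured compounds named here, two measured steps concern the hydroxyphenyl group. a number at least 75 percentage points lower from compound 1 to compound 2 (beyond the scatter), a large fall. a number at least 75 percentage points lower from compound 1 to compound 3 (beyond the scatter), again a large fall. a step that the two limits leave unreadable from compound 2 to compound 3. Taken together, a hydroxy on this phenyl ring carried the whole read-out in compound 1, but only in the one position tried there; the position of compound 3 lost it all. Going by the values given here, no measured compound carries a 4-hydroxyphenyl, so the step to compound 4 is open in size, and the expectation is for a rise out of the limit of modest to large size, a number at least 35 percentage points higher from compound 3 to compound 4 (beyond the scatter), with wide uncertainty. The estimated value for compound 4 in this assay is 45%, expected to fall between 10% and 80%.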

Compound 4, a percentage reported as inhibition, at one concentration (the size of the read-out at that concentration, not a potency): 22%
The estimate for compound 4 lay 23 percentage points above the measured number; the measured number falls inside the stated range.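

In this assay, the placing of the hydroxy on the phenyl ring now reads as three distinct levels: the change to 4-hydroxyphenyl gives a number at least 12 percentage points higher from compound 3 to compound 4 (beyond the scatter), while the same group gives a number 63 percentage points lower from compound 1 to compound 4 (beyond the scatter), so it recovers only part of what 3-hydroxyphenyl carries. Hydroxy in place of hydrogen also gives a number at least 12 percentage points higher from compound 2 to compound 4 (beyond the scatter), which shows that a hydroxy outside the 3-hydroxyphenyl arrangement can still count for something on this ring, a point that compound 3 alone could not show. Both of these rises are readable only as minimum sizes, because compound 2 and compound 3 each stand at a limit: the limit of < 10% in this assay, at which 2 of the 4 values shown sit.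

From the compounds shown here alone, the step between compound 2 and compound 3 cannot be read, so it remains unknown whether 2-hydroxyphenyl differs at all from the ring without a hydroxy. Going by these compounds, it also remains open whether the read-out of 3-hydroxyphenyl depends on the hydroxy as such or would persist with a methoxy, an amine or a carboxylic acid in that place.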